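The compounds below may be only part of what the source reports. "The series", "measured", "known", "first", "only" and "open" are said of these compounds alone.

Compound 1 `COc1ccc(/C=C\C(=O)N2N=C(c3ccncc3)OC2c2c[nH]c3ccccc23)cc1` and compound 2 `O=C(/C=C\c1ccc(Cl)cc1)N1N=C(c2ccncc2)OC1c1c[nH]c2ccccc12` share one core. In an ADME assay on PANC-1 cells (Homo sapiens) for cytotoxicity, read by MTT assay, with a stated time of 48 h (on this read-out higher numbers stand for weaker inhibition of growth and lower numbers for stronger inhibition of growth), compound 1 gives only a limit of the assay, > 30 ug/mL. In this assay compound 2 likewise gives only a limit, > 30 ug/mL. The step that the two limits leave unreadable from compound 1 to compound 2 cannot be sized, since both values sit at the limit of > 30 ug/mL in this assay, at which 2 of the 2 values shown sit. Compound 3 `O=C(/C=C\c1ccc(Cl)cc1Cl)N1N=C(c2ccncc2)OC1c1c[nH]c2ccccc12` differs from compound 2 by chloro in place of hydrogen on an aromatic carbon, ortho to a large group and meta to a chloro group. No readable measured step bears on this change, and compound 2 stands at a limit. Compound 3 is expected to give 30 ug/mL, between 10 ug/mL and 100 ug/mL. The step this estimate means is a number no higher from compound 2 to compound 3 (the limit leaves the size open), expected to stay within the scatter.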

Compound 3, concentration for 50% growth inhibition: > 30 ug/mL
Compound 3 was reported as a limit; the forecaster's own chance of this, stated with the estimate: 70%; the middle value lies on the limit itself.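

No new step can be read among compound 1, compound 2 and compound 3, since all three stand at one limit: the limit of > 30 ug/mL in this assay, at which 3 of the 3 values shown sit. The compounds shown leave open how strongly any of them inhibits growth, and whether swapping these aromatic groups changes it.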